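A few compounds are considered here, and "the series" means these few. Any claim that something is new, unique, unknown or untested is made for them only; others in the source may bear on it.

Measured in an assay on isolated protein for binding affinity to adenosine receptor A1 (Bos taurus); on this read-out lower numbers stand for stronger inhibition and higher numbers for weaker inhibition:

compound 1 `COc1ccc(C(=O)Nc2nc(-c3ccccc3)nc3c2nnn3Cc2ccccc2F)cc1`: 21900000 nM
compound 2 `CCCCCCNc1nc(-c2ccccc2)nc2c1nnn2Cc1ccccc1Cl`: 31000000 nM
compound 3 `CCNc1nc(-c2ccccc2)nc2c1nnn2Cc1ccccc1Cl`: 463000000 nM

Compound 1 and compound 2 sit within the scatter of each other in this assay, so nothing separates them; compound 3 lies well beyond both, and the gap from compound 1 to compound 3 is the widest among the three. Among the measured compounds shown here, the one single-point step in the set is a 15-fold higher number from compound 2 to compound 3 (1.17 log units; beyond the scatter): a shorter chain on the ring nitrogen goes with a much weaker number.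

Compound 4 `Fc1ccccc1Cn1nnc2c(NC3CCCCC3)nc(-c3ccccc3)nc21` differs from compound 1 in that (cyclohexyl in place of (4-methoxyphenyl)carbonyl on a nitrogen on an aromatic ring). The group entering is a ring of six carbons on the same nitrogen that in compound 2 carries a six-carbon chain, and compound 2 and compound 1 give numbers within the scatter of each other. The step from compound 2 to compound 3 says that a small substituent on this nitrogen weakens binding, while cyclohexyl is not small. For the measured compounds named here, no step in the set directly swaps an aryl carbonyl for a saturated ring, so the expectation rests on compound 2 alone.

Compound 4 is therefore expected near compound 1 and compound 2, with a 1.0-fold higher number from compound 1 to compound 4 (0.00 log units; within the scatter), no step beyond the scatter in either direction. The estimate for compound 4 in this assay is 22000000 nM, between 6000000 nM and 80000000 nM.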

Compound 4, inhibition constant: 1150000 nM
Compound 4: middle estimate off by 19-fold (1.28 log units), on the high side, and the stated range ends above it.
By their numbers in this assay, from the lowest: compound 4; then compounds 1 and 2 (each within the scatter of the next); then compound 3.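

In this assay, the nitrogen on an aromatic ring turns out to discriminate between two substituents that are both large (a 19-fold lower number from compound 1 to compound 4 (1.28 log units; beyond the scatter)), whereas the earlier step showed only the effect of shortening a saturated chain at this position. The change replaces (4-methoxyphenyl)carbonyl with cyclohexyl, removing the carbonyl, the methoxy group and the aromatic ring of carbon in a single move, so this one step cannot assign the lower number to any one of those parts. Nothing available explains the size of this step, and no measurement on the compounds bears on it.

Cyclohexylcarbonyl or a simple phenyl on this nitrogen would be the natural groups for separating the loss of the carbonyl from the change of ring, and their place in the series remains open. Also open, going by these compounds, is how cyclohexyl compares with a hexyl chain on this nitrogen, as the compounds carrying cyclohexyl and hexyl also differ in the halogen on the benzyl group, leaving no comparison at this position alone.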